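The compounds below may be only part of what the source reports. "The series", "measured", "known", "first", "only" and "open" are said of these compounds alone.

Compound 1 `CCCCN(C)C(=O)CCCOc1cc(OC)c(OC)c2oc(-c3ccc(OC)cc3)c(O)c(=O)c12`: > 40000 nM
Compound 2 `CCCCCN(C)C(=O)CCCCCOc1cc(OC)c(OC)c2oc(-c3ccc(OC)cc3)c(O)c(=O)c12`: 17200 nM

In a functional assay on A549 cells (Homo sapiens) for antiproliferative activity, read by sulforhodamine B assay, with a stated time of 48 h (on this read-out higher numbers stand for weaker inhibition and lower numbers for stronger inhibition), compound 1 gives > 40000 nM, which is a limit and not a number. Going by the values given here, compound 2 gives 17200 nM, the only actual number so far. Compound 3 `COc1ccc(-c2oc3c(OC)c(OC)cc(OCCCCCC(=O)N4CCN(C)CC4)c3c(=O)c2O)cc1` carries 4-methylpiperazin-1-yl in place of methyl(pentyl)amino on a carbonyl carbon. Among the compounds with values here, the single measured step, an at least 2.3-fold lower number from compound 1 to compound 2 (0.36 log units; beyond the scatter), changes the chain as well as the amine, so it bears only loosely on this swap. The expected step is a 1.2-fold higher number from compound 2 to compound 3 (0.07 log units; within the scatter), none beyond the scatter. For compound 3 the estimated value in this assay is 20000 nM, with an expected range of 7000 nM to 40000 nM.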

Compound 3, half-maximal inhibitory concentration: 14800 nM
Compound 3: middle estimate off by 1.4-fold (0.13 log units), on the high side; the measured number falls inside the stated range.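

In this assay, putting 4-methylpiperazin-1-yl in place of methyl(pentyl)amino on the carbonyl carbon gives a 1.2-fold lower number from compound 2 to compound 3 (0.07 log units; within the scatter), so a ring and an open chain on this amide cannot be told apart here. The other step, an at least 2.7-fold lower number from compound 1 to compound 3 (0.43 log units; beyond the scatter), alters the chain as well as the amine and sets only a bound. Compound 1 stands at a limit and not a number: the limit of > 40000 nM in this assay, at which 1 of the 3 values shown sits. From the compounds shown here alone, it remains open whether a morpholine or a carboxylic acid at this carbonyl carbon, or a longer chain bearing 4-methylpiperazin-1-yl, would read differently.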